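The compounds below may be only part of what the source reports. "The series", "measured", "known", "first", "only" and "open" are said of these compounds alone.

Measured in a functional assay on PC-3 cells (Homo sapiens) for inhibition, read by MTT assay, with a stated time of 72 h; on this read-out higher numbers stand for weaker inhibition and lower numbers for stronger inhibition:
- compound 1 `FC(F)(F)c1ccc(CSc2nc(N3CCNCC3)cc(C(F)(F)F)n2)cc1`: 15900 nM
- compound 2 `CCN1CCN(c2cc(C(F)(F)F)nc(SCc3ccc(C(F)(F)F)cc3)n2)CC1`: 27200 nM
- compound 3 `FC(F)(F)c1ccc(CSc2nc(Sc3nnnn3-c3ccccc3)cc(C(F)(F)F)n2)cc1`: 45300 nM

Compound 3 at 45300 nM lies within the scatter of compound 2 at 27200 nM. Compound 1 at 15900 nM shows a lower number, and that gap lies beyond the scatter.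

Compound 4 `Cc1nnc(Sc2cc(C(F)(F)F)nc(SCc3ccc(C(F)(F)F)cc3)n2)s1` carries 5-methyl-1,3,4-thiadiazol-2-yl in place of 1-phenyl-1H-tetrazol-5-yl on a sulfur.

Among the measured compounds shown here, no measured step makes a change on this sulfur. For the measured compounds named here, the only measured step is ethyl in place of hydrogen on an amine nitrogen in a ring, a 1.7-fold higher number from compound 1 to compound 2 (0.23 log units; within the scatter), and it bears only indirectly, as a sign that one change in this small series moved the number by no more than the scatter. No step beyond the scatter is therefore expected in this assay, and the data set no firm direction.

The estimated step is a 1.5-fold lower number from compound 3 to compound 4 (0.18 log units; within the scatter).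

For compound 4 the expected value is 30000 nM, with an estimated range of 12000 nM to 65000 nM.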

Compound 4, half-maximal inhibitory concentration: > 50000 nM
Compound 4 gave a limit, no number (the forecaster's own chance of this, stated with the estimate: 10%); middle value at least 1.6-fold (0.22 log units) away from the limit.
By their numbers in this assay, from the lowest: compounds 1, 2 and 3 (each within the scatter of the next, the first and the last beyond it). At a limit, above all of these: compound 4.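

Compound 4 in this assay stands at a limit and not a number: the limit of > 50000 nM in this assay, at which 1 of the 4 values shown sits. As far as these compounds go, on the sulfur, 5-methyl-1,3,4-thiadiazol-2-yl in place of 1-phenyl-1H-tetrazol-5-yl gives an at least 1.1-fold higher number from compound 3 to compound 4 (0.04 log units; that floor lies within the scatter), and (5-methyl-1,3,4-thiadiazol-2-yl)sulfanyl in place of 4-ethylpiperazin-1-yl gives an at least 1.8-fold higher number from compound 2 to compound 4 (0.26 log units; that floor lies within the scatter), so neither floor separates these pairs and the true size of either step remains unknown. Among the compounds shown here, the first separated step at this position is (5-methyl-1,3,4-thiadiazol-2-yl)sulfanyl in place of piperazin-1-yl on the aromatic carbon, with an at least 3.1-fold higher number from compound 1 to compound 4 (0.49 log units; beyond the scatter).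

From the compounds shown here alone, how far the true value of compound 4 lies past its limit remains open. Also open, going by these compounds, is whether a simple amine such as morpholine, or a carboxylic acid on a short chain attached through this sulfur, would read closer to the piperazin-1-yl compound.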